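A few compounds are considered here, and "the series" means these few. Any claim that something is new, unique, unknown or untested is made for them only; others in the source may bear on it.

Measured in a physicochemical assay for solubility, measured as thermodynamic solubility, at pH 6.8; a higher number here means a more soluble compound, a lower number a less soluble compound:
- Compound 1 `O=C(O)[C@H]1CC[C@H](c2cc3cccnc3c(-c3cccc(F)c3)n2)CC1`: 0.92 ug/mL
- Compound 2 `N#Cc1cccc(-c2nc(N3CCC(C(=O)O)CC3)cc3cccnc23)c1`: > 4 ug/mL, a limit of the assay and not a number
- Compound 3 `N#Cc1cccc(-c2nc([C@H]3CC[C@H](C(=O)O)CC3)cc3cccnc23)c1`: 0.43 ug/mL

Compound 3 has the lowest reading of the three in this assay, at 0.43 ug/mL. Compound 4 `O=C(O)[C@H]1CC[C@H](c2cc3cccnc3c(-c3cccc(Cl)c3)n2)CC1` has not been measured. It differs from compound 3 by one change, chloro in place of cyano on an aromatic carbon, meta to a large group: chloro in place of cyano on an aromatic carbon.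

The closest guide is a change at the same place, where cyano replaced fluoro: a 2.1-fold lower number from compound 1 to compound 3 (0.33 log units; beyond the scatter). That step was modest. The other step, an at least 9.3-fold lower number from compound 2 to compound 3 (0.96 log units; beyond the scatter), swaps 4-carboxypiperidin-1-yl for 4-carboxycyclohexyl, a different group, and so says little here. Going by the values given here, compound 4 loses the cyano, but it gains chloro rather than fluoro, and no measured compound carries chloro. A small rise at most therefore seems likely, and none beyond the scatter is expected: the estimated step is a 1.2-fold higher number from compound 3 to compound 4 (0.07 log units; within the scatter). For compound 4 the expected value is 0.5 ug/mL, with an estimated range of 0.2 ug/mL to 1.2 ug/mL.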

Compound 4, solubility: 0.14 ug/mL
For compound 4 the middle estimate is 3.6-fold (0.55 log units) above the measured one; measured number below the stated range.
By their numbers in this assay, from the lowest: compound 4; then compound 3; then compound 1. At a limit, above all of these: compound 2.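

In this assay, chloro in place of cyano on this aromatic carbon gives a 3.1-fold lower number from compound 3 to compound 4 (0.49 log units; beyond the scatter), so a second swap at this position also shifts the reading beyond the scatter. Chloro in place of fluoro on the same carbon gives a 6.6-fold lower number from compound 1 to compound 4 (0.82 log units; beyond the scatter), a larger step than either swap involving cyano alone suggested. Across these three compounds, which differ only at this carbon, the number falls from fluoro through cyano to chloro, and nothing measured here explains that order.

As far as these compounds go, whether that order extends to other groups on this carbon, such as an amine or a methoxy group, stays open. From the compounds shown here alone, the 4-carboxypiperidin-1-yl group of compound 2 appears only alongside cyano, so it also stays open whether chloro would lower the number on that compound too.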